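This account rests on a few compounds, and the source may have more. Where it says the series, first, only, none or still open, it means among the compounds named here.

Within the data shown here, in a functional assay on HCT-116 cells (Homo sapiens) for cytotoxicity, read by sulforhodamine B assay, with a stated time of 24 h (a lower number here means a stronger inhibitor, a higher number a weaker inhibitor), compound 2 `O=C1Nc2ccc(S(=O)(=O)N3CCOCC3)cc2/C1=N/NS(=O)(=O)c1ccccc1` gives 13300 nM, the highest of the three numbers so far, though its gap to each neighbour is within the scatter. Compound 1 `N#CCC(=O)N/N=C1\C(=O)Nc2ccc(S(=O)(=O)N3CCOCC3)cc21` gives 10300 nM, and compound 3 `N=c1oc2ccccc2cc1C(=O)N/N=C1\C(=O)Nc2ccc(S(=O)(=O)N3CCOCC3)cc21` gives 6750 nM. The two measured steps both alter the substituent on the amine nitrogen or the carbonyl carbon of the shared core: a 1.3-fold higher number from compound 1 to compound 2 (0.11 log units; within the scatter), and a 1.5-fold lower number from compound 1 to compound 3 (0.18 log units; within the scatter); neither moves the number beyond the scatter. Compound 4 `O=C1Nc2ccc(S(=O)(=O)N3CCOCC3)cc2/C1=N/c1ccc(Cl)cc1` is built from compound 2 by a change of a different kind: 4-chlorophenyl in place of (phenylsulfonyl)amino on a double-bonded nitrogen. Neither measured step replaces the (phenylsulfonyl)amino group itself, so the only bearing they have is that substituent changes at this end of the core have so far left the number within the scatter. Compound 4 is therefore expected to give a number close to that of compound 2, with a 1.3-fold lower number from compound 2 to compound 4 (0.12 log units; within the scatter) as the expected step. The estimate for compound 4 is 10000 nM, with a range from 3000 nM to 35000 nM.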

Compound 4, half-maximal inhibitory concentration: 24300 nM
Estimate against measurement, compound 4: 2.4-fold (0.39 log units) below; low and high end bracket the measured number.
By their numbers in this assay, from the lowest: compounds 3, 1, 2 and 4 (each within the scatter of the next, the first and the last beyond it).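

In this assay, the first change shown that puts an aryl group directly on the double-bonded nitrogen, 4-chlorophenyl in place of (phenylsulfonyl)amino, gives a 1.8-fold higher number from compound 2 to compound 4 (0.26 log units; within the scatter), so this exchange, which also removes the hydrogen-bond donor and acceptors of the leaving group, stays inside the scatter. Among these compounds, the same entering group, set against the ((cyanomethyl)carbonyl)amino group, gives a 2.4-fold higher number from compound 1 to compound 4 (0.37 log units; beyond the scatter), the only single-place step so far printed as beyond the scatter, and a modest one. No measurement given here speaks to the reason for this difference.

The compounds shown leave open whether the chlorine or the phenyl ring accounts for the step. A plain phenyl, a benzyl group or a 4-aminophenyl group on the same nitrogen would separate these parts.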